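Working notes on the step from compound 3 to compound 4

The source may report more compounds than this note shows. Statements on the series, on what has been measured and on what is new or still open speak of the compounds shown alone.

Measured so far in a functional assay on HCT-116 cells (Homo sapiens) for inhibition, read by sulforhodamine B assay, with a stated time of 48 h; a higher number here means a weaker inhibitor of growth, a lower number a stronger inhibitor of growth:
compound 1 `COc1cc(-c2cc(/C=C/C(=O)c3ccc(N)cc3)[nH]n2)cc(OC)c1OC` gives 2610 nM;
compound 2 `COc1cc(-c2cc(/C=C/C(=O)c3ccc(Cl)c(Cl)c3)[nH]n2)cc(OC)c1OC` gives 21500 nM;
compound 3 `COc1ccc(C(=O)/C=C/c2cc(-c3cc(OC)c(OC)c(OC)c3)n[nH]2)cc1OC` gives 2630 nM.

Compound 3 and compound 1 give numbers within the scatter of each other, while compound 2 gives the highest number of the three, with an 8.2-fold lower number from compound 2 to compound 3 (0.91 log units; beyond the scatter) and an 8.2-fold higher number from compound 1 to compound 2 (0.92 log units; beyond the scatter) both beyond the scatter. Compound 4 `COc1ccc(C(=O)/C=C/c2cc(-c3cc(OC)c(OC)c(OC)c3)n[nH]2)cc1` differs from compound 3 by hydrogen in place of methoxy on an aromatic carbon. Within the data shown here, no measured step removes a single substituent from this ring; the steps at hand swap the whole aryl group on the carbonyl carbon, namely a 1.0-fold higher number from compound 1 to compound 3 (0.00 log units; within the scatter) and an 8.2-fold lower number from compound 2 to compound 3 (0.91 log units; beyond the scatter), one within the scatter and one modest. For compound 4 the expected step is a 1.1-fold higher number from compound 3 to compound 4 (0.06 log units; within the scatter), with no clear direction. The estimate for compound 4 in this assay is 3000 nM, between 1200 nM and 8000 nM.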

Compound 4, concentration for total growth inhibition: 5860 nM
The estimate for compound 4 lay 2.0-fold (0.29 log units) below the measured number; low and high end bracket the measured number.
By their numbers in this assay, from the lowest: compounds 1 and 3 (each within the scatter of the next); then compound 4; then compound 2.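

Hydrogen in place of methoxy gives a 2.2-fold higher number from compound 3 to compound 4 (0.35 log units; beyond the scatter) in this assay and is the only step here that removes a single substituent from this ring, so the methoxy ortho to a methoxy group has a measurable bearing on the number. The 4-methoxyphenyl group of compound 4 still compares well with the 3,4-dichlorophenyl group, with a 3.7-fold lower number from compound 2 to compound 4 (0.56 log units; beyond the scatter) on record, but not with the amino-bearing aryl group, with a 2.2-fold higher number from compound 1 to compound 4 (0.35 log units; beyond the scatter) on record. Nothing measured accounts for these steps.

Open, on these data alone, is whether hydroxy or fluorine at this place would match methoxy, and what removing the remaining methoxy would do.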